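Adding a methoxy to an inactive benzyl ether

The source may report more compounds than this note shows. Statements on the series, on what has been measured and on what is new or still open speak of the compounds shown alone.

- compound 1 `COC(=O)N1[C@@H]2C=C[C@@](OC)(C(=O)c3c2cc(OC)c(OC)c3OCc2ccccc2)N1C(=O)OC`: > 300 ug/mL
- compound 2 `COc1cc2c(c(OC)c1OC)C(=O)[C@]1(OC)C=C[C@H]2N(C(=O)OCC(C)C)N1C(=O)OCC(C)C`: > 300 ug/mL

Both compounds were tested in an ADME assay on KB cells (Homo sapiens) for cytotoxicity; on this read-out lower numbers stand for an effect already at smaller amounts and higher numbers for an effect only at larger amounts of compound. In this assay compound 1 gives > 300 ug/mL, which is a limit of the assay and not a number. Compound 2 gives > 300 ug/mL, which is also a limit. Together, the data show (the limit of > 300 ug/mL in this assay, at which 2 of the 2 values shown sit), so compound 1 stands at this limit and no exact value is available for it.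

Compound 3 `COC(=O)N1[C@@H]2C=C[C@@](OC)(C(=O)c3c2cc(OC)c(OC)c3OCc2ccc(OC)cc2)N1C(=O)OC` changes the benzyl of compound 1 to 4-methoxybenzyl, with methoxy in place of hydrogen on an aromatic carbon. Within the data shown here, no measured pair shows the effect of this change. The expected change is a number no higher from compound 1 to compound 3 (the limit leaves the size open), with no step beyond the usual scatter and no expected direction. For compound 3 the estimate is 300 ug/mL, with an expected range from 100 ug/mL to 600 ug/mL.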

Compound 3, concentration for half-maximal effect: > 300 ug/mL
Compound 3: only a limit was reported; the forecaster's own chance of this, stated with the estimate: 70%; the middle value lies on the limit itself.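

In this assay, compound 1 and compound 3 both give only a limit and not a number, so no step can be read for the added methoxy: the limit of > 300 ug/mL in this assay, at which 3 of the 3 values shown sit.

The compounds shown leave open whether benzyl and 4-methoxybenzyl differ at all in this cytotoxicity read-out.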